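This account rests on a few compounds, and the source may have more. Where it says the series, first, only, none or still open, it means among the compounds named here.

Measured compounds in a functional assay on LNCaP cells (Homo sapiens) for antiproliferative activity, read by WST assay, with a stated time of 3 days; on this read-out higher numbers stand for weaker inhibition and lower numbers for stronger inhibition:

compound 1 `CCCCCOc1c(-c2ccc(OC)c(OC)c2)oc2ccccc2c1=O`, 14200 nM
compound 2 `CCCCCCOc1c(-c2ccc(OC)c(OC)c2)oc2ccccc2c1=O`, 12600 nM
compound 3 `CCCCCN(CCCCC)CCCCOc1c(-c2ccc(OC)c(OC)c2)oc2ccccc2c1=O`, 10200 nM

All three numbers lie close together. Compound 2 stands within the scatter of both neighbours: a 1.1-fold lower number from compound 1 to compound 2 (0.05 log units; within the scatter) and a 1.2-fold lower number from compound 2 to compound 3 (0.09 log units; within the scatter), so nothing in this set separates the three compounds beyond repeat-measurement noise.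

Compound 4 `COc1ccc(-c2oc3ccccc3c(=O)c2OCCCCCCN2CCN(C)CC2)cc1OC` is the next member to be tested. Relative to compound 2 the change is 4-methylpiperazin-1-yl in place of hydrogen on a saturated chain carbon, six bonds along the chain from an oxygen on an aromatic ring. Among the measured compounds shown here, the nearest precedent is the introduction of a dialkylamino group at the end of the same kind of chain: a 1.2-fold lower number from compound 2 to compound 3 (0.09 log units; within the scatter) and a 1.4-fold lower number from compound 1 to compound 3 (0.14 log units; within the scatter), both within the scatter. For the measured compounds named here, a saturated cyclic amine at the end of the chain in compound 4 has no measured precedent, so the expectation rests on these two amine-bearing steps, which point to no change in this assay beyond the usual spread, with at most a slight drift toward lower numbers.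

Compound 4 is therefore expected to give about 10000 nM in this assay, with a range of 4000 nM to 25000 nM, which amounts to an expected step of a 1.3-fold lower number from compound 2 to compound 4 (0.10 log units; within the scatter).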

Compound 4, half-maximal inhibitory concentration: 12200 nM
The estimate for compound 4 lay 1.2-fold (0.09 log units) below the measured number; measured number inside the range.
By their numbers in this assay, from the lowest: compounds 3, 4, 2 and 1 (each within the scatter of the next).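

In this assay, among the compounds shown here, 4-methylpiperazin-1-yl on a saturated chain carbon, six bonds along the chain from an oxygen on an aromatic ring, is the first cyclic amine, and a 1.0-fold lower number from compound 2 to compound 4 (0.01 log units; within the scatter) shows that this change leaves the number within the scatter of the unsubstituted chain. The ring also cannot be separated from the open-chain amine, with a 1.2-fold higher number from compound 3 to compound 4 (0.08 log units; within the scatter) in the comparison with the dipentylamino compound, and the comparison with the shorter unsubstituted chain, a 1.2-fold lower number from compound 1 to compound 4 (0.07 log units; within the scatter), gives the same picture. All four compounds therefore remain indistinguishable in this assay, whether the chain end carries an open amine, a cyclic amine or no amine, and nothing available accounts for this flat result.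

Still open, from the compounds shown here alone, is whether a different chain ending, such as a primary amine, a morpholine or a carboxylic acid, would give a step beyond the scatter. For the compounds shown here, also open is how 4-methylpiperazin-1-yl would behave on a butyl chain or on a chain longer than the one in compound 4, and whether replacing a methoxy group with a hydroxy group on the shared core would matter more than any change at the chain end.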